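Removing the phenyl from a hydroxyethylene pepsin inhibitor

The source may hold more compounds than are shown below. What is called first, only, known or untested is meant among the compounds shown, and "the series" means these compounds.

Compound 1 `CC(C)CCNC(=O)C(C)NC(=O)C(Cc1ccccc1)C[C@H](O)[C@H](CC(C)C)NC(=O)C(NC(=O)CC(C)C)C(C)C` was measured in an assay on isolated protein for inhibition of Pepsin A (Sus scrofa) (a higher number here means a weaker inhibitor, a lower number a stronger inhibitor), and gave 2.5 nM. Of the two compounds measured, compound 1 has the lowest number; the other, compound 2 `CC(C)CCNC(=O)C(C)NC(=O)CC(=O)C(CC(C)C)NC(=O)C(NC(=O)CC(C)C)C(C)C`, gives 56 nM in this assay, and the two values show that compound 1 is the stronger inhibitor of the pair. Compound 3 `CC(C)CCNC(=O)C(C)NC(=O)C(C)C[C@H](O)[C@H](CC(C)C)NC(=O)C(NC(=O)CC(C)C)C(C)C` shares the core of compound 1 and differs from it in one place: hydrogen in place of phenyl on a saturated chain carbon, two bonds along the chain from a carbonyl carbon. Among the compounds with values here, no measured pair shows this change, so its effect is an expectation. Compound 1 with its value of 2.5 nM carries the phenyl, and compound 3 is expected to lose inhibition without it, a step from compound 1 to compound 3 of a 12-fold higher number from compound 1 to compound 3 (1.08 log units; beyond the scatter) in this assay. For compound 3 the estimated value in this assay is 30 nM, expected between 8 nM and 150 nM.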

Compound 3, inhibition constant: 3 nM
The estimate for compound 3 lay 10-fold (1.00 log units) above the measured number; the measured number lies below the stated range.
By their numbers in this assay, from the lowest: compounds 1 and 3 (each within the scatter of the next); then compound 2.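

In this assay the change from benzyl to methyl on a saturated chain carbon, two bonds along the chain from a carbonyl carbon, gives a 1.2-fold higher number from compound 1 to compound 3 (0.08 log units; within the scatter) and so leaves inhibition of this enzyme unchanged within the scatter. Within the data shown here, this is the first direct reading of this position: with the rest of the core of compound 1 held constant, the phenyl is not required for the inhibition seen here. Nothing available explains why the change is tolerated.

On these data alone, whether the position accepts other groups remains open, since an amine, a carboxylic acid or a longer chain in place of the methyl could behave differently from either benzyl or methyl. The compounds shown also leave open whether this tolerance extends to any other enzyme, as this assay is the only read-out here.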